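The compounds below may be only part of what the source reports. "The series", "measured", "known", "first", "only" and "open" are said of these compounds alone.

The study compares three thiosemicarbazide-type compounds in a functional assay on A-375 cells (Homo sapiens) for cytotoxicity, read by MTT assay, with a stated time of 72 h (on this read-out higher numbers stand for weaker inhibition and lower numbers for stronger inhibition), and then turns to a fourth that has not yet been tested. Compound 1 `N/C(=N\NC(=S)N1CCN(c2ccccn2)CC1)c1ccc(F)cn1` gives 1400 nM in this assay. Compound 2 `N/C(=N\NC(=S)N1CCCC1)c1ccc(F)cn1` gives 860 nM in this assay. Compound 3 `Cc1cccc(/C(N)=N/NC(=S)N2CCSCC2)n1` gives 1400 nM in this assay, which is the same number as that of compound 1 at the digits given, and the number of compound 2 lies within the usual scatter of both, so the three measured compounds cannot be told apart on these readings.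

Compound 4 `N/C(=N\NC(=S)N1CCSCC1)c1ccccn1` differs from compound 3 in one place: hydrogen in place of methyl on an aromatic carbon next to the ring nitrogen. Within the data shown here, no pair among the measured compounds isolates this change, so there is no measured step to lean on. Since the measured compounds sit so close together, the step from compound 3 to compound 4 is expected to be small, a 1.1-fold higher number from compound 3 to compound 4 (0.03 log units; within the scatter), with no direction beyond the scatter favoured. Compound 4 is therefore estimated at 1500 nM in this assay, with a plausible range from 600 nM to 4000 nM.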

Compound 4, half-maximal inhibitory concentration: 760 nM
Compound 4: middle estimate off by 2.0-fold (0.30 log units), on the high side; measured number inside the range.
By their numbers in this assay, from the lowest: compounds 4, 2, 1 and 3 (each within the scatter of the next).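

Among these compounds, the pair compound 3 and compound 4 is the first to isolate hydrogen in place of methyl on an aromatic carbon, and in this assay this change next to the ring nitrogen gives a 1.8-fold lower number from compound 3 to compound 4 (0.27 log units; within the scatter). That step stays within the scatter, so on this single pair the methyl group at this position is not required for the cytotoxic reading on these cells, and its removal does not separate compound 4 from compound 3. Nothing among the data shown explains the small step between the two compounds.

Only hydrogen and methyl are compared at this position, so the compounds shown leave open whether a chlorine atom, a methoxy group, an amine or a longer chain there would move the reading beyond the scatter. They also leave open whether hydrogen in place of methyl would give a similar result alongside the other end groups carried by compound 1 and compound 2, since neither compound forms a matched pair with compound 3 or compound 4.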